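Removing the Methoxy Group from a Weak Topoisomerase Inhibitor

The source may report more compounds than this note shows. Statements on the series, on what has been measured and on what is new or still open speak of the compounds shown alone.

Compound 2 `COc1c(N2CC[C@@H](CN)C2)c(F)cc2c(=O)c(C(=O)O)cn(Cc3cc(-c4ccccc4)no3)c12` is the only one of the three measured compounds for which an assay on isolated protein for inhibition of DNA topoisomerase 1 (Homo sapiens), with a stated time of 15 min (on this read-out lower numbers stand for stronger inhibition and higher numbers for weaker inhibition), returns a number, 178000 nM. Compound 1 `COc1c(N2CC[C@@H](CN)C2)c(F)cc2c(=O)c(C(=O)O)cn(Cc3ccc(-n4cccn4)cc3)c12` reaches only the limit of this assay, > 200000 nM. Compound 3 `COc1c(N2CC[C@@H](C(N)=O)C2)c(F)cc2c(=O)c(C(=O)O)cn(Cc3ccc(-c4ccccc4)cc3)c12` likewise sits at a limit, > 200000 nM. Going by the values given here, the single step between measured compounds, an at least 1.1-fold lower number from compound 1 to compound 2 (0.05 log units; that floor lies within the scatter), comes from placing 3-phenyl-1,2-oxazol-5-yl in place of 4-(1H-pyrazol-1-yl)phenyl, and its floor lies within the scatter; that comparison is shaped by the limit of > 200000 nM in this assay, at which 2 of the 3 values shown sit. Compound 4 `NC[C@@H]1CCN(c2cc3c(cc2F)c(=O)c(C(=O)O)cn3Cc2cc(-c3ccccc3)no2)C1` has not yet been measured in this assay. It differs from compound 2 in one place: hydrogen in place of methoxy on an aromatic carbon. No measured step touches this position, so nothing among the shown values speaks for a shift in either direction, and the expectation rests on compound 2 alone. The expected step is a 1.1-fold higher number from compound 2 to compound 4 (0.05 log units; within the scatter), which lies within the scatter. Compound 4 is therefore estimated at 200000 nM in this assay, with a range from 80000 nM to 500000 nM, and with a real chance that only a limit is reported.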

Compound 4, half-maximal inhibitory concentration: 58300 nM
Compound 4: the middle estimate sits 3.4-fold (0.54 log units) above what was measured; the whole stated range lies above it.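

Hydrogen in place of methoxy, on the aromatic carbon ortho to the 3-(aminomethyl)pyrrolidin-1-yl group, gives in this assay a 3.1-fold lower number from compound 2 to compound 4 (0.48 log units; beyond the scatter), a modest change. Going by these compounds alone, this is the first step that lies beyond the scatter and joins two numbers, so it shows that this position bears on the read-out and that the methoxy group is not required for the inhibition seen with compound 2. The one earlier step offered only a floor, and what the series can show about other positions remains restricted by the assay's upper end: the limit of > 200000 nM in this assay, at which 2 of the 4 values shown sit.

Going by these compounds, the finding rests on a single pair, which carries the 3-phenyl-1,2-oxazol-5-yl group, so it remains open whether the same change would lower the number in the setting of compound 1, with its 4-(1H-pyrazol-1-yl)phenyl group, or of compound 3, with its different group on the pyrrolidine. The compounds shown also leave open whether hydrogen itself is what matters at this carbon, or whether a fluorine atom, a hydroxyl group, an ethoxy group or an amine there would give a lower or a higher number.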